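Adding a Third Methoxy Group to Compound 1

This account rests on a few compounds, and the source may have more. Where it says the series, first, only, none or still open, it means among the compounds named here.

Compound 1 `COc1ccc(C(=O)/C=C/c2cc(-c3cc(OC)c(OC)c(OC)c3)n[nH]2)cc1OC`: 1590 nM in a functional assay on OVCAR-5 cells (Homo sapiens) for inhibition, read by sulforhodamine B assay, with a stated time of 48 h; a lower number here means a stronger inhibitor of growth, a higher number a weaker inhibitor of growth
Compound 2 `COc1ccc(C(=O)/C=C/c2cc(-c3cc(OC)c(OC)c(OC)c3)n[nH]2)cc1`: 1880 nM in this assay

Compound 1 has the smaller number of the two recorded in this assay, but the step of a 1.2-fold higher number from compound 1 to compound 2 (0.07 log units; within the scatter) lies within the scatter, so the two compounds are not distinguished by these data. Compound 3 `COc1cc(C(=O)/C=C/c2cc(-c3cc(OC)c(OC)c(OC)c3)n[nH]2)cc(OC)c1OC` differs from compound 1 by methoxy in place of hydrogen on an aromatic carbon. Among the measured compounds shown here, the only measured step that bears on this change is the one from compound 1 to compound 2, which removes a methoxy group from that same ring and does not move the number beyond the scatter. Adding one more methoxy group to that ring is therefore expected to leave this assay essentially unchanged, a 1.1-fold lower number from compound 1 to compound 3 (0.03 log units; within the scatter). On that basis compound 3 is estimated at 1500 nM, with a range from 600 nM to 4000 nM.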

Compound 3, concentration for 50% growth inhibition: 1640 nM
For compound 3 the middle estimate is 1.1-fold (0.04 log units) below the measured one; low and high end bracket the measured number.
By their numbers in this assay, from the lowest: compounds 1, 3 and 2 (each within the scatter of the next).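

In this assay the added methoxy group gives a 1.0-fold higher number from compound 1 to compound 3 (0.01 log units; within the scatter) and so extends the earlier finding from removal of a methoxy group to addition of one. A methoxy group in place of hydrogen on this aromatic carbon, ortho to a methoxy group and meta to a large group, therefore leaves the number within the scatter, and compound 1 and compound 3 are not distinguished by these data. No measurement is available that would explain this result.

As far as these compounds go, what remains open is whether a different group at this position, such as an amine, a carboxylic acid or a longer chain like butoxy, would move the number beyond the scatter. The compounds shown also leave open whether replacing the methoxy groups on the other aromatic ring would matter.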